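This account rests on a few compounds, and the source may have more. Where it says the series, first, only, none or still open, it means among the compounds named here.

Compound 1 `COc1cc(COCc2cn(Cc3cc(C)cnc3Cl)nn2)cc(OC)c1OC`: 41900 nM
Compound 2 `COc1cc(COCc2cn(Cc3cc(-c4ccc(C)cc4)cnc3Cl)nn2)cc(OC)c1OC`: 150000 nM

In a functional assay on A549 cells (Homo sapiens) for cytotoxicity, read by MTT assay, with a stated time of 48 h (on this read-out higher numbers stand for weaker inhibition and lower numbers for stronger inhibition), compound 2, at 150000 nM, has the higher of the two numbers and so shows the weaker inhibition. Compound 3 `COc1cc(COCc2cn(Cc3cc(-c4ccccc4)cnc3Cl)nn2)cc(OC)c1OC` differs from it in one place: hydrogen in place of methyl on an aromatic carbon. For the measured compounds named here, only one measured step bears on this: a 3.6-fold higher number from compound 1 to compound 2 (0.55 log units; beyond the scatter), a modest move that came with a much larger swap, 4-methylphenyl in place of methyl. The effect of the lone methyl has not been measured, so little change is expected, with no step beyond the scatter. The expected change is a 1.3-fold lower number from compound 2 to compound 3 (0.10 log units; within the scatter). For compound 3 the estimated value is 120000 nM, with an expected range of 55000 nM to 240000 nM.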

Compound 3, half-maximal inhibitory concentration: 62600 nM
Beside the measured number, compound 3's estimate is 1.9-fold (0.28 log units) above it, within the range that was stated.
By their numbers in this assay, from the lowest: compounds 1 and 3 (each within the scatter of the next); then compound 2.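

In this assay, removing only the methyl from the 4-methylphenyl group gives a 2.4-fold lower number from compound 2 to compound 3 (0.38 log units; beyond the scatter), so this single carbon, para to a large group, is enough to shift the result beyond the scatter. Phenyl in place of the methyl of the core gives a 1.5-fold higher number from compound 1 to compound 3 (0.17 log units; within the scatter), which is within the scatter, so the weaker inhibition of compound 2 appears here only with the added methyl on the phenyl ring. Nothing available explains why this methyl matters. Still open, on these data alone, is how other groups at this spot, such as fluorine, methoxy or an amine, would compare with hydrogen and methyl.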